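This account rests on a few compounds, and the source may have more. Where it says the series, first, only, none or still open, it means among the compounds named here.

Compound 1 `O=C(/C=C/CN1CCCC1)Nc1cc2c(N3CCc4ccccc43)ncnc2cc1O[C@@H]1CCOC1`: 2230 nM
Compound 2 `O=C(/C=C/CN1CCCCC1)Nc1cc2c(N3CCc4ccccc43)ncnc2cc1O[C@@H]1CCOC1`: 4660 nM
Compound 3 `COc1cc2ncnc(N3CCCc4ccccc43)c2cc1NC(=O)/C=C/CN1CCCC1`: 2230 nM

All three were tested in a functional assay on A549 cells (Homo sapiens) for antiproliferative activity, read by MTT assay, with a stated time of 72 h; on this read-out lower numbers stand for stronger inhibition and higher numbers for weaker inhibition. Compound 2 differs from compound 1 in one place, (piperidin-1-yl in place of pyrrolidin-1-yl on a saturated chain carbon bound to a double-bonded chain carbon), and that change gave a 2.1-fold higher number from compound 1 to compound 2 (0.32 log units; beyond the scatter). Compound 3 carries a different core from compound 1; the difference between the two cores is not broken down here. In this assay compound 3 gives 2230 nM, and compound 1 gives 2230 nM, so these two sit together within the usual scatter and stand apart from compound 2.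

Compound 4 `COc1cc2ncnc(N3CCCc4ccccc43)c2cc1NC(=O)/C=C/CN1CCCCC1` has not yet been measured. For the measured compounds named here, it differs from compound 3 by piperidin-1-yl in place of pyrrolidin-1-yl on a saturated chain carbon bound to a double-bonded chain carbon, which is the same change, at the same place, as the one from compound 1 to compound 2. If the change behaves on the core of compound 3 as it did on the core of compound 1, compound 4 is expected to show a step of about a 2.1-fold higher number from compound 3 to compound 4 (0.31 log units; beyond the scatter), resting on the measured 2.1-fold higher number from compound 1 to compound 2 (0.32 log units; beyond the scatter) and on the value of compound 3, 2230 nM. On that basis compound 4 is estimated at 4600 nM, with a likely range from 2500 nM to 8500 nM.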

Compound 4, half-maximal inhibitory concentration: 2880 nM
Compound 4: the middle estimate sits 1.6-fold (0.20 log units) above what was measured; low and high end bracket the measured number.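

In this assay, putting piperidin-1-yl in place of pyrrolidin-1-yl on the core of compound 3 gave a 1.3-fold higher number from compound 3 to compound 4 (0.11 log units; within the scatter). Set beside the earlier step on the core of compound 1, this result gives no firm sign that the core alters the effect of the change: the same change on two cores in this assay, a 2.1-fold higher number (0.32 log units; beyond the scatter) from compound 1 to compound 2 and a 1.3-fold higher number (0.11 log units; within the scatter) from compound 3 to compound 4, 1.6-fold (0.21 log units) apart, within the scatter of two such steps. For the compounds shown here, this does not prove that the step has the same size on both cores, since only one of the two steps lies beyond the scatter, and a single pair on each core cannot establish a rule for the whole series.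

The compounds shown leave open how other amines on the same chain, such as morpholin-4-yl or dimethylamino, would compare with pyrrolidin-1-yl and piperidin-1-yl. They also leave open whether the same change would give a similar step on further cores or in a different cell line.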